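This account rests on a few compounds, and the source may have more. Where it says the series, first, only, none or still open, it means among the compounds named here.

Going by the values given here, in an ADME assay on microsomes from liver (Mus musculus) for metabolic stability, with a stated time of 10 min, tested at 0.5 uM (a lower number here means that less of the compound is left, a higher number that more of the compound is left), compound 1 (`CCC(c1nc2ncc(Cl)cc2[nH]1)[C@H]1CC[C@@H](c2ccnc3ccc(C(F)(F)F)cc32)CC1`) gives 57%, the higher of the two numbers measured so far. Compound 2 (`C[C@@H](c1nnc(-c2ccc(Cl)cc2)o1)[C@H]1CC[C@@H](c2ccnc3ccc(F)cc32)CC1`) gives 41%, and that gap lies beyond the usual scatter of repeat measurements. Compound 3 (`CCC(c1nc2ncc(Cl)cc2[nH]1)[C@H]1CC[C@@H](c2ccnc3ccc(F)cc32)CC1`) is the next one to consider. It has fluoro in place of trifluoromethyl on an aromatic carbon, and the swap can be counted as fluoro in place of trifluoromethyl on an aromatic carbon. The rest of the structure of compound 1 stays the same. Among the compounds with values here, no measured pair shows this swap on its own, so the data give no direct guide to its size. A small fall is expected, probably not beyond the scatter, with compound 2 at 41% as the only lower reference point. The estimated step is a number 7 percentage points lower from compound 1 to compound 3 (within the scatter). For compound 3, the expected value is 50%, with an estimated range from 33% to 68%.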

Compound 3, percent of the compound remaining: 7%
Compound 3: the middle estimate sits 43 percentage points above what was measured; the whole stated range lies above it.
By their numbers in this assay, from the lowest: compound 3; then compound 2; then compound 1.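

In this assay, fluoro in place of trifluoromethyl on this aromatic carbon comes out as a number 50 percentage points lower from compound 1 to compound 3 (beyond the scatter) with the rest of the structure unchanged. Going by these compounds alone, this is the first pair in the set to differ in one place only, and it shows that the group at this single position can by itself decide whether much of the compound is left or very little. Nothing available explains why the swap has so large an effect.

The compounds shown leave open how other groups on this aromatic carbon, such as a nitrile or a methoxy group, would compare with trifluoromethyl and fluoro. They also leave open whether the same swap would give a step of similar size on a different core.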